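Swapping cyclobutyloxy for propyl: a clearance estimate

This account rests on a few compounds, and the source may have more. Where it says the series, first, only, none or still open, it means among the compounds named here.

compound 1 (`C[C@@H]1CN(c2sc(CN(C)C)nc2-c2nc3ccccc3[nH]2)CCN1C(=O)Cn1cnc2cccnc21`) gives 44 mL.min-1.g-1
compound 2 (`CCOc1ncc(-c2nc(C(F)(F)F)sc2N2CCN(C(=O)Cn3cnc4ccccc43)[C@H](C)C2)cn1`) gives 662 mL.min-1.g-1
compound 3 (`Cc1nc(C)n(CC(=O)N2CCN(c3sc(C(F)(F)F)nc3-c3cnc(OC4CCC4)nc3)C[C@H]2C)n1`) gives 51 mL.min-1.g-1

All three numbers come from a toxicity assay on microsomes from liver (Homo sapiens) for metabolic stability, read by LC-MS, using NADPH, tested at 1 uM (a higher number here means faster removal of the compound, a lower number slower removal), and describe how quickly liver enzymes remove each compound. Compound 3 lies within the usual scatter of compound 1, so these two cannot be told apart. Compound 2 stands far higher, well beyond the scatter of compound 3.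

The next compound, compound 4 (`CCCc1ncc(-c2nc(C(F)(F)F)sc2N2CCN(C(=O)Cn3nc(C)nc3C)[C@H](C)C2)cn1`), keeps most of compound 3 but carries propyl in place of cyclobutyloxy on an aromatic carbon, between two ring nitrogen atoms (propyl in place of cyclobutyloxy on an aromatic carbon). Among the compounds with values here, no two measured compounds differ in one place only, and none carries propyl, so the data show no direct effect of this swap. Within the data shown here, the starting point is therefore compound 3 (51 mL.min-1.g-1), the one measured compound a single change away. In this assay, no shift beyond the scatter is expected in either direction, and the estimated step is small (a 1.1-fold lower number from compound 3 to compound 4 (0.05 log units; within the scatter)). Compound 2 (662 mL.min-1.g-1) shows that much higher numbers occur among these compounds, so the expected range is wider on the upper side. The expected value for compound 4 is estimated at 45 mL.min-1.g-1 (range 18 mL.min-1.g-1 to 130 mL.min-1.g-1).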

Compound 4, intrinsic clearance in microsomes: 80 mL.min-1.g-1
Compound 4: the middle estimate sits 1.8-fold (0.25 log units) below what was measured, and the stated range covers the measured number.
By their numbers in this assay, from the lowest: compounds 1, 3 and 4 (each within the scatter of the next); then compound 2.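

Within the data shown here, this is the first pair that differs in one place only, so the swap can now be read directly. In this assay, putting propyl in place of cyclobutyloxy, on the aromatic carbon between two ring nitrogen atoms, gives a 1.6-fold higher number from compound 3 to compound 4 (0.20 log units; within the scatter). At this position, then, the group can lose its oxygen, its four-membered ring and its hydrogen-bond acceptor, and the removal of the compound by liver enzymes still cannot be told apart from that of the parent. No separate measurement bears on what lies behind this outcome.

On these data alone, only these two groups are compared at this position, so it remains open whether a longer chain such as butyl, an amine or a carboxylic acid on the same carbon would also leave the number within the scatter. As far as these compounds go, it is also open whether the swap from 2-(cyclobutyloxy)pyrimidin-5-yl to 2-propylpyrimidin-5-yl would read the same on a compound carrying the different groups found elsewhere in compound 2, whose own number is much higher.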